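This account rests on a few compounds, and the source may have more. Where it says the series, first, only, none or still open, it means among the compounds named here.

Compound 1 `CC(=O)N[C@@H](CC(C)C)C(=O)NCC(CC(=O)O)S(=O)(=O)N[C@H](C(N)=O)[C@@H](C)O` — in an assay (Mus musculus) with mucosal addressin cell adhesion molecule 1 (Homo sapiens) as the target (a higher number here means a weaker inhibitor, a lower number a stronger inhibitor), compound 1 gives only a limit of the assay, > 500000 nM.
Compound 2 `CC(=O)N[C@@H](CC(C)C)C(=O)NCC(CC(=O)O)S(=O)(=O)N[C@H](C(N)=O)C(C)C` — in this assay compound 2 gives 219000 nM.
Compound 3 `CC(=O)N[C@@H](CC(C)C)C(=O)N[C@@H](CC(=O)O)C(=O)N[C@H](C(N)=O)[C@@H](C)O` — in this assay compound 3 gives 276000 nM.

All three compounds share the same core and all are weak inhibitors. The number for compound 3 and the number for compound 2 lie within the usual scatter of each other, so no order can be read between them; compound 1 is known only as a limit, at the limit of > 500000 nM in this assay, at which 1 of the 3 values shown sits.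

Compound 4 `CC(=O)N[C@@H](CC(C)C)C(=O)N[C@@H](CC(=O)O)C(=O)N[C@H](C(N)=O)C(C)C` has not yet been measured. It differs from compound 3 in one place: isopropyl in place of 1-hydroxyethyl on a saturated chain carbon bound to an amide-type nitrogen and a carbonyl carbon. The same exchange, on a closely related pair, has been seen once: an at least 2.2-fold lower number from compound 1 to compound 2 (0.35 log units; beyond the scatter). Because that step starts from a limit (the limit of > 500000 nM in this assay, at which 1 of the 3 values shown sits), only its smallest possible size is known, which is already beyond the scatter. For compound 4 a step of similar direction is therefore expected, a 2.0-fold lower number from compound 3 to compound 4 (0.29 log units; within the scatter), a modest move towards stronger inhibition. Compound 4 is expected to give about 140000 nM, with a likely range from 60000 nM to 350000 nM.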

Compound 4, half-maximal inhibitory concentration: 126000 nM
For compound 4 the middle estimate is 1.1-fold (0.05 log units) above the measured one; low and high end bracket the measured number.
By their numbers in this assay, from the lowest: compounds 4, 2 and 3 (each within the scatter of the next, the first and the last beyond it). At a limit, above all of these: compound 1.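

In this assay, the exchange of 1-hydroxyethyl for isopropyl now has a measured size: a 2.2-fold lower number from compound 3 to compound 4 (0.34 log units; beyond the scatter). Both ends of this step are numbers and neither is a limit. The earlier step gave only a smallest possible size. The exchange now lowers the number on two cores, so its direction is not tied to a single core, though two examples are all there is: the same change on two cores in this assay, an at least 2.2-fold lower number (0.35 log units; beyond the scatter) from compound 1 to compound 2 and a 2.2-fold lower number (0.34 log units; beyond the scatter) from compound 3 to compound 4; the limit leaves it open whether they differ

On these data alone, whether the two steps differ in size stays open, since the value of compound 1 is a limit: the limit of > 500000 nM in this assay, at which 1 of the 4 values shown sits. Also open is whether the oxygen of 1-hydroxyethyl or the added carbon of isopropyl drives the step, and how a methyl group, a longer chain such as isobutyl, or an amine would behave on this saturated chain carbon.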